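Swapping fluoro for methyl on the aryl of compound 3

The compounds below may be only part of what the source reports. "The series", "measured", "known", "first", "only" and "open" are said of these compounds alone.

Of the compounds shown here, three built on one shared core have been measured in a functional assay on HT-29 cells (Homo sapiens) for cytotoxicity, read by MTT assay, with a stated time of 72 h; on this read-out lower numbers stand for stronger inhibition and higher numbers for weaker inhibition. Compound 1 `COc1cc2c(Oc3ccc(NC(=O)c4nnn(-c5ccccc5C)c4C)cc3F)ccnc2cc1OCCCN1CCCC1` gives 450 nM. Compound 2 `COc1cc2c(Oc3ccc(NC(=O)c4nnn(-c5ccccc5C(F)(F)F)c4C)cc3F)ccnc2cc1OCCCN1CCCC1` gives 200 nM, and a 2.3-fold lower number from compound 1 to compound 2 (0.35 log units; beyond the scatter). Compound 3 `COc1cc2c(Oc3ccc(NC(=O)c4nnn(-c5ccc(F)cc5)c4C(F)(F)F)cc3F)ccnc2cc1OCCCN1CCCC1` gives 120 nM; its number is separated from that of compound 2 by a gap within the scatter, and from that of compound 1 by a gap beyond it, so compound 3 and compound 2 cannot be told apart on these numbers, while both sit clearly away from compound 1.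

Compound 4 `COc1cc2c(Oc3ccc(NC(=O)c4nnn(-c5ccc(C)cc5)c4C(F)(F)F)cc3F)ccnc2cc1OCCCN1CCCC1` differs from compound 3 by a single change: methyl in place of fluoro on an aromatic carbon. Among the compounds with values here, only one measured step exists in this set, and it concerns methyl giving way to trifluoromethyl, a different pair of groups; it was modest in size. Within the data shown here, no measured pair compares fluoro with methyl directly. Among the measured compounds shown here, the move to compound 4 therefore has no direct precedent, and no shift beyond the scatter in this assay is expected in either direction. The expected step is a 1.3-fold higher number from compound 3 to compound 4 (0.12 log units; within the scatter). Compound 4 is estimated at 160 nM, with a range from 60 nM to 420 nM.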

Compound 4, half-maximal inhibitory concentration: 550 nM
Estimate against measurement, compound 4: 3.4-fold (0.54 log units) below; the measured number lies above the stated range.
By their numbers in this assay, from the lowest: compounds 3 and 2 (each within the scatter of the next); then compounds 1 and 4 (each within the scatter of the next).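

In this assay, the change from 4-fluorophenyl to 4-methylphenyl replaces just one heavy atom with another, adds no ring and no net charge, and still gives a 4.6-fold higher number from compound 3 to compound 4 (0.66 log units; beyond the scatter). Within the data shown here, this is the first measured sign that the group on this aromatic carbon, para to a large group, matters for the read-out, since the only earlier step involved a different pair of groups and so could say nothing about this place. Among these compounds, in both measured steps, the compound with methyl has the higher number, although that rests on only two pairs with different partners for methyl, and nothing available here indicates what lies behind the new step.

At this place the compounds shown carry only fluoro and methyl, so it remains open how a chlorine atom, a methoxy group, an amine, a carboxylic acid or a longer chain such as ethyl would read. Also open, on these data alone, is whether the same swap would give a similar step in a compound carrying methyl instead of the trifluoromethyl found elsewhere in compound 3 and compound 4.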